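A few compounds are considered here, and "the series" means these few. Any claim that something is new, unique, unknown or untested is made for them only; others in the source may bear on it.

Working notes on the series. In a functional assay (aorta) with Rattus norvegicus as the target (on this read-out higher numbers stand for an effect only at larger amounts of compound and lower numbers for an effect already at smaller amounts), compound 1 `CCNC1=NS(=O)(=O)c2cc(F)ccc2N1` returns only a limit, > 300 uM. Going by the values given here, compound 2 `CCNC1=NS(=O)(=O)c2cc(Cl)ccc2N1` gives 39.9 uM and compound 3 `CNC1=NS(=O)(=O)c2cc(Br)ccc2N1` gives 31 uM, two numbers within the scatter of each other, so compound 3 has compound 2 as its only numeric neighbour.

Compound 4 `CCNC1=NS(=O)(=O)c2cc(Br)ccc2N1` follows from compound 3 by methyl in place of hydrogen on a saturated chain carbon bound to an amine nitrogen, which turns methylamino into ethylamino. The aromatic substituent of compound 3 stays.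

Among the compounds with values here, the only measured step, an at least 7.5-fold lower number from compound 1 to compound 2 (0.87 log units; beyond the scatter), is chloro in place of fluoro on an aromatic carbon. It is a sizeable step, but it does not touch the chain, so it bears on this change only indirectly. Its size is also only a bound because of the limit of > 300 uM in this assay, at which 1 of the 3 values shown sits.

The closer guide is compound 2, which already carries ethylamino at 39.9 uM. Within the data shown here, no measured step isolates the chain change, so the range stays wide. The expected change in this assay is a 1.0-fold lower number from compound 3 to compound 4 (0.01 log units; within the scatter), which is no step beyond the scatter. For compound 4 the estimated value is 30 uM, with an expected range of 12 uM to 75 uM.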

Compound 4, concentration for half-maximal effect: 6.2 uM
Compound 4: the middle estimate sits 4.8-fold (0.68 log units) above what was measured; the whole stated range lies above it.
By their numbers in this assay, from the lowest: compound 4; then compounds 3 and 2 (each within the scatter of the next). At a limit, above all of these: compound 1.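

Going by these compounds alone, the chain change from methylamino to ethylamino, with bromo held in place, gives a 5.0-fold lower number from compound 3 to compound 4 (0.70 log units; beyond the scatter); this is the first measured step in this assay that isolates the change, and it shows that this chain position affects the read-out. With ethylamino held in place, bromo in place of chloro gives a 6.4-fold lower number from compound 2 to compound 4 (0.81 log units; beyond the scatter), so the aromatic substituent still moves the number beyond the earlier fluoro to chloro step, and among the three ethylamino compounds the numbers fall from fluoro through chloro to bromo. Bromo in place of fluoro gives an at least 48-fold lower number from compound 1 to compound 4 (1.68 log units; beyond the scatter), and the size of this step is only a bound: the limit of > 300 uM in this assay, at which 1 of the 4 values shown sits.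

The compounds shown leave open whether a longer chain such as propyl or a branched one such as isopropyl on the amine nitrogen would lower the number further or reverse the trend. As far as these compounds go, it also remains open whether the methylamino to ethylamino step has the same size with chloro or fluoro on the aromatic carbon, and how iodo or trifluoromethyl would compare with bromo there.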